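The compounds below may be only part of what the source reports. "The series", "measured", "known", "first", "only" and "open" are said of these compounds alone.

Measured in an ADME assay on MCF-10A cells (Homo sapiens) for cytotoxicity, read by MTT assay, with a stated time of 72 h; a higher number here means a weaker inhibitor of growth, a lower number a stronger inhibitor of growth:
- compound 1 `CS/C(=N\C(=O)c1csc([N+](=O)[O-])c1)NC(=O)c1csc([N+](=O)[O-])c1` gives 1550 nM
- compound 2 `CS/C(=N\C(=O)c1ccco1)NC(=O)c1ccco1` gives 8220 nM
- compound 3 `O=C(/N=C(/NC(=O)c1cc(-c2ccccc2)nc2ccccc12)[Se]Cc1ccccc1)c1cc(-c2ccccc2)nc2ccccc12` gives 8460 nM

Compound 1 holds the lowest number of the three; its gaps to compound 2 and to compound 3 both lie beyond the scatter, so it is the strongest inhibitor of growth among them.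

Compound 4 `O=C(/N=C(/NC(=O)c1csc([N+](=O)[O-])c1)[Se]Cc1ccccc1)c1csc([N+](=O)[O-])c1` is not yet measured in this assay. Its structural change from compound 1 is a group of 8 heavy atoms (7 carbon, 1 selenium; one six-membered aromatic ring of carbon only) in place of a group of 2 heavy atoms (1 carbon, 1 sulfur; no ring), on a carbon with a double bond to nitrogen. For the measured compounds named here, no step of this kind has been measured here, so the direction is open; compound 3, the only other compound carrying the same entering group, sits at the high end of the range, which suggests a modest rise rather than a fall. The step from compound 1 to compound 4 is expected to be a 1.8-fold higher number from compound 1 to compound 4 (0.26 log units; within the scatter). For compound 4 the estimate is 2800 nM, within 900 nM to 8500 nM.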

Compound 4, concentration for 50% growth inhibition: 24400 nM
The estimate for compound 4 lay 8.7-fold (0.94 log units) below the measured number; the measured number lies above the stated range.
By their numbers in this assay, from the lowest: compound 1; then compounds 2 and 3 (each within the scatter of the next); then compound 4.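

In this assay the carbon with a double bond to nitrogen proves sensitive to its substituent: the group of 8 heavy atoms (7 carbon, 1 selenium) in place of methylsulfanyl gives a 16-fold higher number from compound 1 to compound 4 (1.20 log units; beyond the scatter) in the first step read at this place. Nothing measured here bears on the origin of this step. From the compounds shown here alone, the selenium and the six-membered aromatic ring enter together, so their separate contributions remain open. A benzylsulfanyl group or a methylselanyl group at this place would separate them.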